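Methyl added to the side chain of compound 1

The compounds below may be only part of what the source reports. "The series", "measured", "known", "first", "only" and "open" are said of these compounds alone.

Compound 1 `CC(C)C(NC(=O)NO)C(=O)NC1CCCCC1` is the parent of this pair. In a functional assay on HEp-2 cells (Homo sapiens) for inhibition (a lower number here means a stronger inhibitor, a higher number a weaker inhibitor), compound 1 gives > 100000 nM, which is a limit of the assay and not a number, as shown by the limit of > 100000 nM in this assay, at which 1 of the 2 values shown sits. Compound 2 `CCC(C)C1NC(=O)N(C2CCCCC2)C1=O` has a different core; in this assay compound 2 gives 69700 nM. Among the compounds with values here, compound 3 `CCC(C)C(NC(=O)NO)C(=O)NC1CCCCC1` differs from compound 1 by methyl in place of hydrogen on a saturated chain carbon, three bonds along the chain from an amide-type nitrogen and a carbonyl carbon; no measured step matches this change. The expected step from compound 1 to compound 3 is a step that the limit leaves unreadable from compound 1 to compound 3, none beyond the scatter. Compound 3 is estimated at 120000 nM, between 30000 nM and 400000 nM.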

Compound 3, half-maximal inhibitory concentration: > 100000 nM
Compound 3 gave a limit, no number; the forecaster's own chance of this, stated with the estimate: 60%; the middle value does not contradict the limit.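

Compound 1 and compound 3 both give only a limit of the assay, not a number, so no step can be read between them: the limit of > 100000 nM in this assay, at which 2 of the 3 values shown sit.

The compounds shown leave open whether methyl in place of hydrogen on this side chain changes inhibition at all.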